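The compounds below may be only part of what the source reports. "The series", "measured", "known", "first", "only" and "open" are said of these compounds alone.

Compound 1 `COc1cc2c(/C=C3/C(=O)Nc4ccc(Cl)cc43)c(Cl)n(Cc3cc(OC)c(OC)c(OC)c3)c2cc1C` and compound 2 `COc1ccc2c(c1)/C(=C\c1c(Cl)n(Cc3cc(OC)c(OC)c(OC)c3)c3cc(C)c(OC)cc13)C(=O)N2` share one core and differ in a single place. In a functional assay on NSCLC cells (Homo sapiens) for cytotoxicity, with a stated time of 48 h (on this read-out lower numbers stand for stronger inhibition of growth and higher numbers for weaker inhibition of growth), compound 1 gives 2290 nM, and compound 2 gives 20400 nM. The change that separates them is methoxy in place of chloro on an aromatic carbon, and it produced an 8.9-fold higher number from compound 1 to compound 2 (0.95 log units; beyond the scatter), a weakening of growth inhibition that lies well beyond the usual scatter of the measurement.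

Compound 3 `COc1c(/C=C2/C(=O)Nc3ccc(Cl)cc32)c2ccccc2n1-c1ccccc1` is built on a different core; the difference between the two cores is not broken down here. In this assay compound 3 gives 9550 nM, which stands between the two values of the first pair.

Compound 4 `COc1ccc2c(c1)/C(=C\c1c(OC)n(-c3ccccc3)c3ccccc13)C(=O)N2` has not yet been measured. It arises from compound 3 through (methoxy in place of chloro on an aromatic carbon), which is the same change as that from compound 1 to compound 2, made at the same place. Compound 4 is therefore expected to give about 48000 nM in this assay. That expectation means a step of a 5.0-fold higher number from compound 3 to compound 4 (0.70 log units; beyond the scatter), and it rests on one precedent, because an 8.9-fold higher number from compound 1 to compound 2 (0.95 log units; beyond the scatter) weakened growth inhibition on the other core. Within the data shown here, since only one such precedent exists, the expected range for compound 4 is wide, from 15000 nM to 150000 nM.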

Compound 4, concentration for 50% growth inhibition: 2510 nM
For compound 4 the middle estimate is 19-fold (1.28 log units) above the measured one; measured number below the stated range.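

In this assay, methoxy in place of chloro on an aromatic carbon gave a 3.8-fold lower number from compound 3 to compound 4 (0.58 log units; beyond the scatter), so growth inhibition became stronger on this core, whereas the same change weakened it on the core of compound 1. Among these compounds, the effect of this change therefore did not carry over from one core to the other, and the two steps run in opposite directions: the same change on two cores in this assay, an 8.9-fold higher number (0.95 log units; beyond the scatter) from compound 1 to compound 2 and a 3.8-fold lower number (0.58 log units; beyond the scatter) from compound 3 to compound 4, 34-fold (1.53 log units) apart, beyond the scatter of two such steps With only one pair on each core, this result shows that the core can reverse the outcome of the change, but it does not show why, nor which direction a further core would follow.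

The compounds shown leave open how a fluoro group, an amine or a carboxylic acid would behave at this place in place of chloro or methoxy. They also leave open which part of the difference between the two cores decides the direction of the step.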